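Swapping the ketone aryl group in a benzothiazole series

The compounds below may be only part of what the source reports. "The series", "measured", "known", "first", "only" and "open" are said of these compounds alone.

Three enaminone compounds sharing a benzothiazole core have been tested in a functional assay on A549 cells (Homo sapiens) for antiproliferative activity, read by sulforhodamine B assay, with a stated time of 48 h; on this read-out higher numbers stand for weaker inhibition and lower numbers for stronger inhibition. Compound 2 `COc1cc(OC)c2sc(-c3ccc(N/C=C\C(=O)c4cc(OC)c(OC)c(OC)c4)cc3)nc2c1` gives 21800 nM. Compound 1 `COc1ccc2nc(-c3ccc(N/C=C\C(=O)c4ccc(OC)c(O)c4)c(C)c3)sc2c1` gives 18000 nM, and compound 3 `COc1cc(OC)c2sc(-c3ccc(N/C=C\C(=O)c4ccc(OC)c([N+](=O)[O-])c4)c(C)c3)nc2c1` gives 12100 nM. Compound 2 thus shows the highest number of the three, yet its gaps to compound 1 and to compound 3 both fall within the scatter, so no ranking can be read from them. Compound 4 `COc1cc(OC)c2sc(-c3ccc(N/C=C\C(=O)c4ccc(OC)c(O)c4)cc3)nc2c1` differs from compound 2 in one place: 3-hydroxy-4-methoxyphenyl in place of 3,4,5-trimethoxyphenyl on a carbonyl carbon. Going by the values given here, no measured pair isolates this change. The step from compound 2 to compound 4 is expected to stay within the scatter, a 1.2-fold lower number from compound 2 to compound 4 (0.08 log units; within the scatter). Compound 4 is accordingly estimated at 18000 nM in this assay, within a range of 8000 nM to 40000 nM.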

Compound 4, half-maximal inhibitory concentration: 10600 nM
Compound 4: middle estimate off by 1.7-fold (0.23 log units), on the high side, and the stated range covers the measured number.
By their numbers in this assay, from the lowest: compounds 4, 3, 1 and 2 (each within the scatter of the next, the first and the last beyond it).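

In this assay, going by these compounds alone, the aryl group on the ketone gives the first step in this set between compounds that differ in one place: 3-hydroxy-4-methoxyphenyl in place of 3,4,5-trimethoxyphenyl on a carbonyl carbon gives a 2.1-fold lower number from compound 2 to compound 4 (0.31 log units; beyond the scatter) and so lies just past the usual scatter. The earlier compounds shown here offered no such pair, so this position could not be judged from them. No measurement available here bears on the reason for this step.

The compounds shown do not separate the gain of the hydroxyl from the loss of methoxy groups. Going by these compounds, how an amine or a carboxylic acid on this aryl group would read also remains open.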